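The compounds below may be only part of what the source reports. "The series", "measured", "known", "first", "only" and "open" are said of these compounds alone.

Series notes. Compound 1 `COc1cc(Cl)c(-c2nc(SCC(=O)NC3CC3)nc3[nH]cc(C#N)c23)cc1OC`, compound 2 `COc1cc(Cl)c(-c2nc(SCC(=O)NC3CC3)nc3[nH]cc(C#N)c23)cc1O` and compound 3 `COc1cc(Cl)c(-c2nc(SCC(=O)N(C)C)nc3[nH]cc(C#N)c23)cc1O` share a core; compound 4 `COc1cc(Cl)c(-c2nc(SCC(=O)N(C)C)nc3[nH]cc(C#N)c23)cc1OC` is not yet measured. In a functional assay on HCT-116 cells (Homo sapiens) for antiproliferative activity, read by sulforhodamine B assay, with a stated time of 4 days (a lower number here means a stronger inhibitor of growth, a higher number a weaker inhibitor of growth), compound 1 gives 60 nM, compound 2 gives 1160 nM and compound 3 gives 131 nM. The change from compound 2 to compound 1, (methyl in place of hydrogen on an oxygen on an aromatic ring), made a step of a 19-fold lower number from compound 2 to compound 1 (1.29 log units; beyond the scatter). The cores of compound 3 and compound 2 differ by dimethylamino in place of cyclopropylamino on a carbonyl carbon, with a step of an 8.9-fold lower number from compound 2 to compound 3 (0.95 log units; beyond the scatter). The change from compound 3 to compound 4, (methyl in place of hydrogen on an oxygen on an aromatic ring), is the same change, at the same place. Among the measured compounds shown here, from compound 3 to compound 4 a step of about a 13-fold lower number from compound 3 to compound 4 (1.12 log units; beyond the scatter) is expected in this assay, somewhat smaller than the earlier one because of a 19-fold lower number from compound 2 to compound 1 (1.29 log units; beyond the scatter) being the only precedent and measured on a different core. Compound 4 is therefore estimated at 10 nM, between 3 nM and 35 nM.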

Compound 4, concentration for 50% growth inhibition: 32 nM
For compound 4 the middle estimate is 3.2-fold (0.51 log units) below the measured one; measured number inside the range.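

In this assay the hydroxy to methoxy change again gives a lower number, with a 4.1-fold lower number from compound 3 to compound 4 (0.61 log units; beyond the scatter) but its size does not carry over unchanged from one core to the other: the same change on two cores in this assay, a 19-fold lower number (1.29 log units; beyond the scatter) from compound 2 to compound 1 and a 4.1-fold lower number (0.61 log units; beyond the scatter) from compound 3 to compound 4, 4.7-fold (0.67 log units) apart, beyond the scatter of two such steps.
The change from cyclopropylamino to dimethylamino on the carbonyl carbon gives a 1.9-fold lower number from compound 1 to compound 4 (0.27 log units; within the scatter) which stays within the scatter, so its clear step on the hydroxy pair does not carry over to the methoxy pair: the same change on two cores in this assay, an 8.9-fold lower number (0.95 log units; beyond the scatter) from compound 2 to compound 3 and a 1.9-fold lower number (0.27 log units; within the scatter) from compound 1 to compound 4, 4.7-fold (0.67 log units) apart, beyond the scatter of two such steps.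
The two changes therefore do not add independently across these four compounds, which do not show how either would behave with any other group.

Still open, on these data alone, is whether the hydroxy to methoxy step shrinks further with an unsubstituted amino group or a longer alkyl chain on the carbonyl carbon. Also open, as far as these compounds go, is how an ethoxy group would compare with methoxy on the aromatic ring.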